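Microsomal half-life: methyl on the imidazole of compound 2

A few compounds are considered here, and "the series" means these few. Any claim that something is new, unique, unknown or untested is made for them only; others in the source may bear on it.

Measured so far in an ADME assay on microsomes from liver (Rattus norvegicus) for metabolic stability; a lower number here means that the compound disappears faster, a higher number that the compound lasts longer:
- compound 1, `CC(C)C(c1nnc[nH]1)c1ccc(-c2ccc3cccc(F)c3c2)[nH]c1=O`: 0.552 h
- compound 2, `CC(C)C(c1ncc[nH]1)c1ccc(-c2ccc3cccc(F)c3c2)[nH]c1=O`: < 0.0667 h, a limit of this assay, not a number

Compound 2 sits at the limit of < 0.0667 h in this assay, at which 1 of the 2 values shown sits, the lowest point this assay reports. Going by the values given here, the one measured step, an at least 8.2-fold lower number from compound 1 to compound 2 (0.91 log units; beyond the scatter), concerns the ring itself and not a substituent on it. Compound 3, `Cc1c[nH]c(C(c2ccc(-c3ccc4cccc(F)c4c3)[nH]c2=O)C(C)C)n1`, differs from compound 2 by methyl in place of hydrogen on an aromatic carbon. Among the compounds with values here, no measured step covers methyl for hydrogen, so no shift beyond the scatter is expected, and the estimate is that compound 3 again returns only a limit, a step that the limit leaves unreadable from compound 2 to compound 3. Compound 3 is expected at 0.05 h, between 0.02 h and 0.15 h.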

Compound 3, half-life: < 0.0667 h
Compound 3 ended at the assay's limit (the forecaster's own chance of this, stated with the estimate: 70%); the middle value lies beyond the limit too.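

Methyl on this aromatic carbon brings no readable recovery: in this assay compound 3 gives < 0.0667 h, a limit and not a number. The step between the two imidazoles cannot be read, so any effect of methyl in place of hydrogen stays hidden. Putting 4-methyl-1H-imidazol-2-yl in place of 4H-1,2,4-triazol-3-yl gives an at least 8.2-fold lower number from compound 1 to compound 3 (0.91 log units; beyond the scatter).

Open, as far as these compounds go, is whether a larger group here, such as hydroxymethyl or an aminomethyl chain, gives a readable half-life on the imidazole. Also open, from the compounds shown here alone, is what methyl does on the 4H-1,2,4-triazol-3-yl ring, where a half-life can be read.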